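The compounds below may be only part of what the source reports. "The series", "measured", "known", "first", "only" and "open" are said of these compounds alone.

In a functional assay on COLO 205 cells (Homo sapiens) for inhibition, read by sulforhodamine B assay, with a stated time of 48 h, tested at 50 uM (on this read-out higher numbers stand for more inhibition of growth at the one concentration tested and lower numbers for less inhibition of growth), compound 1 `COc1ccc(/C=C/C(=O)/C=C/c2ccc(OCc3cn(CCCCCOc4cc(=O)oc5ccccc45)nn3)c(OC)c2)cc1OC` reaches 43% of inhibition, compound 2 `COc1cc(/C=C/C(=O)/C=C/c2cccc3ccccc23)ccc1OCc1cn(CCCCOc2cc(=O)oc3ccccc23)nn1` reaches 50% of inhibition and compound 3 `COc1cc(/C=C/C(=O)/C=C/c2cc(OC)c(OC)c(OC)c2)ccc1OCc1cn(CCOc2cc(=O)oc3ccccc23)nn1` reaches 86% of inhibition. Compound 2 therefore lies within the scatter of compound 1 and far beyond the scatter from compound 3.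

Compound 4 `COc1ccc(/C=C/C(=O)/C=C/c2ccc(OCc3cn(CCCCOc4cc(=O)oc5ccccc45)nn3)c(OC)c2)cc1` has not yet been measured. It departs from compound 2 in one place: 4-methoxyphenyl in place of naphthalen-1-yl on a double-bonded chain carbon bound to a double-bonded chain carbon with 4-methoxyphenyl in place of naphthalen-1-yl on a double-bonded chain carbon bound to a double-bonded chain carbon.

Going by the values given here, the measured compounds differ from one another in more than one place, so no measured pair isolates this change. The high value of compound 3 at 86% cannot be tied to any single structural feature, and the expectation stays close to compound 2 at 50% in this assay with no step beyond the scatter. The expected step of a number 2 percentage points higher from compound 2 to compound 4 (within the scatter) is small and within the scatter. Compound 4 is expected at 52% with an estimated range of 35% to 72% on the same read-out.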

Compound 4, percent growth inhibition at one concentration: 49%
The estimate for compound 4 lay 3 percentage points above the measured number; measured number inside the range.
By their numbers in this assay, from the lowest: compounds 1, 4 and 2 (each within the scatter of the next); then compound 3.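

In this assay, 4-methoxyphenyl in place of naphthalen-1-yl on a double-bonded chain carbon bound to a double-bonded chain carbon gives a number 1 percentage points lower from compound 2 to compound 4 (within the scatter). This single-place pair shows that, at the one concentration tested, this read-out does not separate the two aromatic groups at this position, even though they differ in aromatic ring count and hydrogen-bond acceptor count. No measurement bearing on the reason for this result is available.

From the compounds shown here alone, whether a 4-aminophenyl or 4-carboxyphenyl group at this position would give a step beyond the scatter remains open. Also open, going by these compounds, is which feature goes with the higher value of compound 3 at 86%, since compound 3 differs from compound 2 and compound 4 in more than one place.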